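This account rests on a few compounds, and the source may have more. Where it says the series, first, only, none or still open, it means among the compounds named here.

Measured compounds:
Compound 1, `COc1nc2ccc(Br)cc2cc1C(c1ccccc1)n1cc(-c2ccc(Br)cc2)nn1`, gives 10.4% in an ADME assay on PANC-1 cells (Homo sapiens) for cytotoxicity, read by sulforhodamine B assay, with a stated time of 48 h, tested at 10 uM; on this read-out higher numbers stand for more inhibition at the one concentration tested (going by the name of the read-out) and lower numbers for less inhibition.
Compound 2, `CCCCCc1cn(C(c2ccccc2)c2cc3cc(Br)ccc3nc2OC)nn1`, gives 5.07% in this assay.

Within the data shown here, compound 2 stands at the lower of the two numbers measured so far in this assay, with compound 1 as its only neighbour; the gap between them is one that repeated measurements of this kind can produce on their own, so the two compounds cannot be ordered against each other.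

Compound 3, `COc1nc2ccc(Br)cc2cc1C(c1ccccc1)n1cc(-c2ccc(F)cc2)nn1`, has not yet been measured. It differs from compound 2 in one place: 4-fluorophenyl in place of pentyl on an aromatic carbon. Among the measured compounds shown here, the only measured step that bears on this change is the reverse one, in which a number 5.3 percentage points lower from compound 1 to compound 2 (within the scatter), and that step did not exceed the scatter. An aromatic ring returning to the same aromatic carbon, now carrying fluorine instead of bromine, is therefore expected to give a step of a number 3.9 percentage points higher from compound 2 to compound 3 (within the scatter), that is, no change beyond the scatter, with a value near that of compound 1 as the most likely outcome.

On this basis compound 3 is estimated to give 9% in this assay, between 0% and 20%.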

Compound 3, a percentage reported as inhibition, at one concentration (the size of the read-out at that concentration, not a potency): 14.9%
Beside the measured number, compound 3's estimate is 5.9 percentage points below it; the measured number falls inside the stated range.
By their numbers in this assay, from the lowest: compounds 2, 1 and 3 (each within the scatter of the next).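

In this assay, 4-fluorophenyl in place of pentyl on the aromatic carbon of the five-membered aromatic ring with 3 nitrogen gives a number 9.8 percentage points higher from compound 2 to compound 3 (within the scatter) and so adds a second aromatic group to set against the one open chain, yet this position still shows no difference beyond the scatter between a chain and a substituted phenyl. Fluoro in place of bromo on the phenyl group, a change the earlier compounds did not cover, gives a number 4.5 percentage points higher from compound 1 to compound 3 (within the scatter) and so cannot be told apart from no change either. No other measurement bears on why the three compounds read as they do.

The compounds shown leave open whether any group on this aromatic carbon can move the number in this assay beyond the scatter. As far as these compounds go, what an amine or a carboxylic acid in place of the halogen on the phenyl group, or a longer chain in place of pentyl, would do to that number also remains open.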